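The source may report more compounds than this note shows. Statements on the series, on what has been measured and on what is new or still open speak of the compounds shown alone.

Measured compounds:
compound 1, `CC(C)c1ccccc1N1CCN(CCCCC(=O)N2Cc3ccccc3C[C@H]2C(N)=O)CC1`, 30 nM;
compound 2, `NC(=O)[C@@H]1Cc2ccccc2CN1C(=O)CCCCN1CCN(c2ccccc2-c2ccccc2)CC1`, 12 nM;
compound 3, `NC(=O)[C@@H]1Cc2ccccc2CN1C(=O)CCCCCCN1CCN(c2ccccc2-c2ccccc2)CC1`, 11 nM.

These numbers come from an assay on HEK293 cells for displacement of a labelled ligand from 5-hydroxytryptamine receptor 7 (Homo sapiens), with a stated time of 1 h; a higher number here means a weaker inhibitor, a lower number a stronger inhibitor. Compound 2 stands second highest of the three. Compound 3 lies within the scatter of it, so no order between those two can be read. Compound 1 lies beyond the scatter, and a 2.5-fold lower number from compound 1 to compound 2 (0.40 log units; beyond the scatter) is the only step shown. Compound 4, `O=C([C@@H]1Cc2ccccc2CN1C(=O)CCCCN1CCN(c2ccccc2-c2ccccc2)CC1)N1CCOCC1`, differs from compound 2 by morpholin-4-yl in place of amino on a carbonyl carbon. No measured step concerns this change, since the single step shown alters the aromatic carbon instead. The expectation therefore rests on the change alone, and a modest move to a higher number is expected, a 2.9-fold higher number from compound 2 to compound 4 (0.46 log units; beyond the scatter). For compound 4 in this assay the estimate is 35 nM, with a range from 9 nM to 140 nM.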

Compound 4, inhibition constant: 9 nM
Estimate against measurement, compound 4: 3.9-fold (0.59 log units) above, within the range that was stated.
By their numbers in this assay, from the lowest: compounds 4, 3 and 2 (each within the scatter of the next); then compound 1.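

In this assay, morpholin-4-yl in place of amino on the carbonyl carbon gives a 1.3-fold lower number from compound 2 to compound 4 (0.12 log units; within the scatter) and so no readable shift in either direction. This position therefore accepts a six-membered non-aromatic ring, and the loss of the amino group's hydrogen-bond donor leaves the number within the scatter in this one pair. Nothing measured here gives a reason for this.

As far as these compounds go, whether other groups on this carbonyl carbon, such as dimethylamino or piperidin-1-yl, would behave alike stays open. So does whether the same swap would hold with the isopropyl of compound 1 or the longer chain of compound 3.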